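The source may hold more compounds than are shown below. What is called first, only, known or untested is meant among the compounds shown, and "the series" means these compounds.

Compound 1 `CC(C)=CCc1cc(C(=O)Nc2cc3ccc(OCC4CCCNC4)c(C)c3oc2=O)ccc1O`: 600 nM
Compound 2 `COC(=O)CNCCCOc1ccc2cc(NC(=O)c3ccc(O)c(CC=C(C)C)c3)c(=O)oc2c1C`: 1060 nM

In a functional assay on SK-BR-3 cells (Homo sapiens) for antiproliferative activity (a higher number here means a weaker inhibitor, a lower number a stronger inhibitor), compound 2 gives 1060 nM, and it cannot be separated from compound 1, which gives 600 nM. The next compound, compound 3 `CC(C)=CCc1cc(C(=O)Nc2cc3ccc(OCCCN(C)C4CCCCC4)c(C)c3oc2=O)ccc1O`, differs from compound 2 in one place: cyclohexyl(methyl)amino in place of ((methoxycarbonyl)methyl)amino on a saturated chain carbon, three bonds along the chain from an oxygen on an aromatic ring. In words, cyclohexyl(methyl)amino stands in place of ((methoxycarbonyl)methyl)amino on a saturated chain carbon, three bonds along the chain from an oxygen on an aromatic ring. Within the data shown here, only one measured step bears on this, a 1.8-fold higher number from compound 1 to compound 2 (0.25 log units; within the scatter), which also exchanged a group on that chain. Among the measured compounds shown here, no measured compound carries the entering group, so the evidence is thin. For the measured compounds named here, with only that small step as a guide, no change beyond the scatter is expected in this assay, and no direction can be firmly expected. The estimated step is a 1.3-fold lower number from compound 2 to compound 3 (0.12 log units; within the scatter). In this assay the estimate for compound 3 is 800 nM, with an expected range of 300 nM to 2200 nM.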

Compound 3, half-maximal inhibitory concentration: 970 nM
Compound 3: the middle estimate sits 1.2-fold (0.08 log units) below what was measured, within the range that was stated.
By their numbers in this assay, from the lowest: compounds 1, 3 and 2 (each within the scatter of the next).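

In this assay, putting cyclohexyl(methyl)amino in place of ((methoxycarbonyl)methyl)amino on the saturated chain carbon gives a 1.1-fold lower number from compound 2 to compound 3 (0.04 log units; within the scatter) and so does not shift the result beyond the scatter, even though the entering group brings a six-membered non-aromatic ring of carbon only and has 0 hydrogen-bond donors. The comparison with the piperidin-3-yl group of compound 1 gives a 1.6-fold higher number from compound 1 to compound 3 (0.21 log units; within the scatter) and is also within the scatter, so the three different groups on this chain cannot be separated in this assay. No measurement offered here accounts for this result.

From the compounds shown here alone, it remains open whether a carboxylic acid in place of the (methoxycarbonyl)methyl group, or a plain alkyl chain with no amine, would move the number beyond the scatter. A longer chain between the oxygen and the amine is equally untested among the compounds shown.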